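Hexylamino replacing the carbamate in the benzothiepine sulfone series

The compounds below may be only part of what the source reports. "The series", "measured", "known", "first", "only" and "open" are said of these compounds alone.

Going by the values given here, compound 3 `CCCC[C@]1(CC)CS(=O)(=O)c2ccc(NC(=O)OCc3ccccc3)cc2[C@@H](c2ccccc2)[C@H]1O` gives 400 nM in an assay on cells for inhibition of ileal sodium/bile acid cotransporter (Homo sapiens) (a lower number here means a stronger inhibitor, a higher number a weaker inhibitor), the second highest of the three numbers measured so far. It sits between compound 1 `CCCC[C@]1(CC)CS(=O)(=O)c2ccc(OC)cc2[C@@H](c2ccccc2)[C@H]1O`, which gives 55 nM, and compound 2 `CCCC[C@]1(CC)CS(=O)(=O)c2ccc(N(O)C(=O)OC(C)(C)C)cc2[C@@H](c2ccccc2)[C@H]1O`, which gives 2670 nM; the step of a 7.3-fold higher number from compound 1 to compound 3 (0.86 log units; beyond the scatter) and the step of a 6.7-fold lower number from compound 2 to compound 3 (0.82 log units; beyond the scatter) place it apart from both beyond the scatter, and the step of a 49-fold higher number from compound 1 to compound 2 (1.69 log units; beyond the scatter) shows how wide the spread from this single aromatic position can be.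

Compound 4 `CCCCCCNc1ccc2c(c1)[C@@H](c1ccccc1)[C@@H](O)[C@](CC)(CCCC)CS2(=O)=O` differs from compound 3 in one place: hexyl in place of benzyloxycarbonyl on a nitrogen on an aromatic ring. Among the compounds with values here, no measured step removes a carbonyl-bearing group from this nitrogen, so the bearing steps are only indirect: the substituent on this aromatic carbon has moved the read-out by modest to large amounts, with the smaller methoxy of compound 1 at the low end. A downward step is therefore expected for compound 4, estimated as a 4.0-fold lower number from compound 3 to compound 4 (0.60 log units; beyond the scatter), landing near compound 1 rather than compound 2. Compound 4 is expected to give 100 nM in this assay, within a range of 25 nM to 400 nM.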

Compound 4, half-maximal inhibitory concentration: 1670 nM
Compound 4: middle estimate off by 17-fold (1.22 log units), on the low side; measured number outside the range, above it.
By their numbers in this assay, from the lowest: compound 1; then compound 3; then compounds 4 and 2 (each within the scatter of the next).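

In this assay the move to hexyl does not bring this nitrogen back toward compound 1: the step of a 4.2-fold higher number from compound 3 to compound 4 (0.62 log units; beyond the scatter) runs upward, and the step of a 30-fold higher number from compound 1 to compound 4 (1.48 log units; beyond the scatter) remains large. The step of a 1.6-fold lower number from compound 2 to compound 4 (0.20 log units; within the scatter) puts hexylamino level with hydroxy(tert-butoxycarbonyl)amino, so all three nitrogen-linked groups shown read weaker than methoxy, with compound 3 the closest to it and no compound going against that. No supporting data on hand bear on why the hexyl chain gives this result.

Still open, as far as these compounds go, is whether the nitrogen itself or the group on it carries the loss, which a free amine or a dimethylamino group on this aromatic carbon would help separate. A shorter butyl chain or a hexyloxy group would show whether chain length or the linking atom matters more.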